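Removing the Aryl Methyl: Compound 4 Expected Unchanged

The source may report more compounds than this note shows. Statements on the series, on what has been measured and on what is new or still open speak of the compounds shown alone.

Measured so far in a functional assay on HepG2 cells (Homo sapiens) for inhibition, read by CCK-8 assay, with a stated time of 48 h; on this read-out higher numbers stand for weaker inhibition and lower numbers for stronger inhibition:
Compound 1 `c1ccc(C2=NN(C3=NC(c4ccccc4)CS3)C(c3cccc4ccccc34)C2)cc1` gives 13200 nM.
Compound 2 `Cc1ccc(C2=NN(C3=NC(c4ccccc4)CS3)C(c3ccc4ccccc4c3)C2)cc1` gives 14700 nM.
Compound 3 `Cc1ccc(C2=NN(C3=NC(=O)CS3)C(c3ccc4ccccc4c3)C2)cc1` gives 12700 nM.

Going by the values given here, compound 2 and compound 1 give numbers that lie within the usual scatter of each other, and the one measured step that starts from compound 2, a 1.2-fold lower number from compound 2 to compound 3 (0.06 log units; within the scatter), is likewise within the scatter. On the numbers shown, nothing separates compound 2 from either of the other two.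

Compound 4 `c1ccc(C2=NN(C3=NC(c4ccccc4)CS3)C(c3ccc4ccccc4c3)C2)cc1` differs from compound 2 in one place: hydrogen in place of methyl on an aromatic carbon. Among the compounds with values here, the only measured step, from compound 2 to compound 3, replaces a group on an amine nitrogen in a ring and leaves the 4-methylphenyl untouched, so no measured step bears directly on the change to compound 4. Compound 1 carries the same phenyl group as compound 4 but a different naphthyl attachment, and its value and that of compound 2 sit within the scatter.

Given that every measured step here is within the scatter, the step of a 1.1-fold lower number from compound 2 to compound 4 (0.02 log units; within the scatter) is expected to be no larger than the scatter in either direction. Compound 4 is therefore estimated at 14000 nM in this assay, with a range from 7000 nM to 28000 nM.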

Compound 4, half-maximal inhibitory concentration: 17200 nM
For compound 4 the middle estimate is 1.2-fold (0.09 log units) below the measured one, within the range that was stated.
By their numbers in this assay, from the lowest: compounds 3, 1, 2 and 4 (each within the scatter of the next).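

In this assay the change from 4-methylphenyl to phenyl now has a measured step of its own: a 1.2-fold higher number from compound 2 to compound 4 (0.07 log units; within the scatter) shows that, on an aromatic carbon para to a large group, hydrogen and methyl cannot be told apart in this read-out. The same compound also gives a direct reading of the naphthyl attachment: a 1.3-fold higher number from compound 1 to compound 4 (0.11 log units; within the scatter) is the step for naphthalen-2-yl in place of naphthalen-1-yl on a saturated ring carbon, and it too stays within the scatter, so neither of these two changes separates the compounds involved. No measurement at hand accounts for either step.

From the compounds shown here alone, only hydrogen and methyl appear at this place, so it remains open whether a larger or different group there, such as an amine, a carboxylic acid or a longer chain, would move the number beyond the scatter. Also open, going by these compounds, is whether the change from 4-methylphenyl to phenyl would read the same with naphthalen-1-yl in the shared core, or with the smaller group on the amine nitrogen that compound 3 carries.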